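Swapping methoxy for amino: expected tissue distribution of compound 4

The source may report more compounds than this note shows. Statements on the series, on what has been measured and on what is new or still open speak of the compounds shown alone.

Among the measured compounds shown here, compound 1 `CCCCCOC(=O)N1CCN(C(=O)[C@H](CCC(=O)O)NC(=O)c2nc(-c3ccccc3)cc(N3CCC(COC)CC3)n2)CC1` is one of three compounds measured in an in vivo ADME assay on the whole organism (strain Sprague-Dawley) for pharmacokinetics, with Rattus norvegicus as the target; on this read-out higher numbers stand for wider distribution into tissues and lower numbers for narrower distribution. Compound 1 gives 0.15 L/kg, the lowest of the three numbers. Compound 3 `CCCCCOC(=O)N1CCN(C(=O)[C@H](CCC(=O)O)NC(=O)c2cc(N3CCC(C(=O)NCC)CC3)nc(-c3ccccc3)n2)CC1` gives 0.2 L/kg, which sits within the usual scatter of the number for compound 1. Compound 2 `CCCCCOC(=O)N1CCN(C(=O)[C@H](CCC(=O)O)NC(=O)c2cc(N3CCC(OCCO)CC3)nc(-c3ccccc3)n2)CC1` gives 0.8 L/kg, well beyond the scatter above compound 1. For the measured compounds named here, the only measured step between two compounds that differ in one place is a 4.0-fold lower number from compound 2 to compound 3 (0.60 log units; beyond the scatter), and that change involves groups on the saturated ring itself rather than the chain that is altered here.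

Compound 4 `CCCCCOC(=O)N1CCN(C(=O)[C@H](CCC(=O)O)NC(=O)c2nc(-c3ccccc3)cc(N3CCC(CN)CC3)n2)CC1` differs from compound 1 by amino in place of methoxy on a saturated chain carbon bound to a saturated ring carbon. Going by the values given here, no measured step bears directly on this change, so the expectation rests only on the spread of the three numbers: the shared core can give values from the low end of compound 1 up to the number of compound 2. For compound 4 the number in this assay is expected to be 0.5 L/kg, with a range of 0.15 L/kg to 1.6 L/kg. That estimate means an expected step of a 3.3-fold higher number from compound 1 to compound 4 (0.52 log units; beyond the scatter), but with the data at hand the direction is uncertain and the step may fall within the scatter.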

Compound 4, volume of distribution at steady state: 0.28 L/kg
For compound 4 the middle estimate is 1.8-fold (0.25 log units) above the measured one; the range from low to high includes it.
By their numbers in this assay, from the lowest: compounds 1, 3 and 4 (each within the scatter of the next); then compound 2.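

In this assay, among the compounds shown here, amino in place of methoxy on a saturated chain carbon bound to a saturated ring carbon gives a 1.9-fold higher number from compound 1 to compound 4 (0.27 log units; within the scatter), the first measured step at this place. On this read-out, then, the 4-(methoxymethyl)piperidin-1-yl and 4-(aminomethyl)piperidin-1-yl groups cannot be told apart, even though the exchange swaps an oxygen-bearing end for one with a hydrogen-bond donor and shortens the group by one heavy atom. No measurement at hand accounts for this small step or says what lies behind it.

This single pair gives one exchange at one place, so it cannot show whether other end groups on the same chain, such as a hydroxyl, a dimethylamino group or a carboxylic acid, would also stay within the scatter of compound 1 or move beyond it. It also leaves open whether a longer chain carrying the amine, with more atoms between the saturated ring and the amino group, would give a different number on the same shared core.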